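Viability on Vero cells: aryl swap at the amide-bearing carbon

The compounds below may be only part of what the source reports. "The series", "measured", "known", "first", "only" and "open" are said of these compounds alone.

Measured so far:
compound 1, `CSc1ccc(C(=O)/C(=C/c2ccccn2)c2ccc(Cl)c(Cl)c2)cc1`, 93.6%
compound 2, `CCOC(=O)C(C(=O)c1ccc(OC)cc1)C(NC(C)=O)c1ccc(C(C)C)cc1`, 96.5%

In an ADME assay on Vero cells (Chlorocebus sabaeus) for cytotoxicity, read by MTT assay, tested at 50 uM (a higher number here means a weaker effect of the compound at the concentration tested, a lower number a stronger effect), compound 2 gives 96.5%, the highest of the two numbers at hand, but its nearest neighbour compound 1 at 93.6% lies within the scatter of it, so the two show no difference that can be read as order. Both compounds leave cell viability almost untouched at the tested concentration.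

Compound 3 is `CCOC(=O)C(C(=O)c1ccc(OC)cc1)C(NC(C)=O)c1cc(OC)ccc1Br`, not yet measured in this assay. It differs from compound 2 as follows: 2-bromo-5-methoxyphenyl in place of 4-isopropylphenyl on a saturated chain carbon bound to an amide-type nitrogen and a saturated chain carbon. Among the compounds with values here, the series holds no step between two measured compounds on which the size of this change could be weighed, so the expectation rests on the two values alone, both of which sit near the top of the read-out.

For compound 3 in this assay a step of a number 3.5 percentage points lower from compound 2 to compound 3 (within the scatter) is expected, that is, none beyond the scatter. The estimate for compound 3 is 93%, with a range from 78% to 100%.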

Compound 3, a percentage reported as activity, at one concentration (the size of the read-out at that concentration, not a potency): 93.3%
Beside the measured number, compound 3's estimate is 0.3 percentage points below it, within the range that was stated.
By their numbers in this assay, from the lowest: compounds 3, 1 and 2 (each within the scatter of the next).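

In this assay, within the data shown here, 2-bromo-5-methoxyphenyl in place of 4-isopropylphenyl on a saturated chain carbon bound to an amide-type nitrogen and a saturated chain carbon gives a number 3.2 percentage points lower from compound 2 to compound 3 (within the scatter) and is the only step at hand. At this position, an aryl group carrying a bromine and a methoxy can thus stand in for one carrying an isopropyl, with no difference beyond the scatter at the tested concentration. No measurement at hand accounts for this result.

On these data alone, the bromine and the methoxy enter together, so their separate contributions in this assay stay open. Also open, as far as these compounds go, is what a carboxylic acid or an amine on the aryl ring at this position would do to the read-out.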